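This account rests on a few compounds, and the source may have more. Where it says the series, first, only, none or still open, it means among the compounds named here.

Compound 1, `CCOC(=O)c1cnnn1CCOCC1=NC(C)=C(C(=O)OC)C(c2ccccc2Cl)/C1=C(\O)OCC`: 100 nM in a functional assay (aorta) with Rattus norvegicus as the target; a lower number here means a stronger inhibitor, a higher number a weaker inhibitor
Compound 2, `CCO/C(O)=C1\C(COCCN2C(=O)CNC2=O)=NC(C)=C(C(=O)OC)C1c1ccccc1Cl`: 31.6 nM
Compound 3, `CCO/C(O)=C1\C(COCCn2c(N)cnc2O)=NC(C)=C(C(=O)OC)C1c1ccccc1Cl`: 158 nM

Compound 3 has the highest number of the three in this assay. Its nearest neighbour is compound 1, and that gap is within the scatter: a 1.6-fold higher number from compound 1 to compound 3 (0.20 log units; within the scatter). The furthest is compound 2, and that gap lies beyond the scatter: a 5.0-fold higher number from compound 2 to compound 3 (0.70 log units; beyond the scatter).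

Compound 4, `CCO/C(O)=C1\C(COCCN2CC(=O)NC2=O)=NC(C)=C(C(=O)OC)C1c1ccccc1Cl`, has not yet been measured. It differs from compound 3 in one place: 2,4-dioxoimidazolidin-1-yl in place of 5-amino-2-hydroxy-1H-imidazol-1-yl on a saturated chain carbon, two bonds along the chain from an oxygen on a saturated carbon.

Within the data shown here, only one measured step bears directly on this change. Compound 2 carries 2,5-dioxoimidazolidin-1-yl at the same place, and the step from compound 2 to compound 3 was modest but beyond the scatter: a 5.0-fold higher number from compound 2 to compound 3 (0.70 log units; beyond the scatter). The group that enters in compound 4, 2,4-dioxoimidazolidin-1-yl, is built from the same atoms as that of compound 2, with one five-membered non-aromatic ring with 2 hetero atoms and 2 double bonds outside aromatic rings. Compound 4 is therefore expected to show a lower number than compound 3 in this assay, with a step of about a 4.0-fold lower number from compound 3 to compound 4 (0.60 log units; beyond the scatter). The estimate for compound 4 is 40 nM, with a range from 15 nM to 110 nM.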

Compound 4, half-maximal inhibitory concentration: 20 nM
Compound 4: middle estimate off by 2.0-fold (0.30 log units), on the high side; low and high end bracket the measured number.
By their numbers in this assay, from the lowest: compounds 4 and 2 (each within the scatter of the next); then compounds 1 and 3 (each within the scatter of the next).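

In this assay, 2,4-dioxoimidazolidin-1-yl in place of 5-amino-2-hydroxy-1H-imidazol-1-yl gives a 7.9-fold lower number from compound 3 to compound 4 (0.90 log units; beyond the scatter), and the same group in place of 5-(ethoxycarbonyl)-1H-1,2,3-triazol-1-yl gives a 5.0-fold lower number from compound 1 to compound 4 (0.70 log units; beyond the scatter). Together with the earlier steps, this means that among these four compounds both dioxoimidazolidinyl groups give lower numbers than the triazole and imidazole groups, with no compound going against this, while the exchange of one dioxoimidazolidinyl arrangement for the other gives only a 1.6-fold lower number from compound 2 to compound 4 (0.20 log units; within the scatter), so this assay does not separate the two. The data offer no independent measurement that could explain these differences.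

The compounds shown leave open whether a methyl group on the dioxoimidazolidinyl ring, or a six-membered ring carrying the same two carbonyl groups, would keep numbers in this range. They also do not show whether either dioxoimidazolidinyl group would hold its place in this series on a longer chain than the 2-ethoxy link, or how a carboxylic acid at the end of that chain would compare.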